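This account rests on a few compounds, and the source may have more. Where it says the series, first, only, none or still open, it means among the compounds named here.

Two compounds open this series, compound 1, `NC1CCN(Cc2ccn3ncnc(Nc4cccc(F)c4)c23)CC1`, and compound 2, `NC1CCN(Cc2ccn3ncnc(Nc4cccc(Cl)c4)c23)CC1`. In a functional assay on A2780 cells (Homo sapiens) for antiproliferative activity (a higher number here means a weaker inhibitor, a lower number a stronger inhibitor), compound 1 gives > 5000 nM, which is a limit of the assay and not a number. Compound 2 gives > 5000 nM, again a limit. Compound 2 therefore has no measured number of its own and stands at the limit of > 5000 nM in this assay, at which 2 of the 2 values shown sit.

Within the data shown here, putting chloro in place of fluoro gives a step that the two limits leave unreadable from compound 1 to compound 2, so the only measured step offers no size to build on. Compound 3, `COc1ccc(Nc2ncnn3ccc(CN4CCC(N)CC4)c23)cc1Cl`, keeps the shared core and adds one group: methoxy in place of hydrogen on an aromatic carbon. This turns 3-chlorophenyl into 3-chloro-4-methoxyphenyl. Among the measured compounds shown here, no measured step involves a methoxy, so the data give neither a size nor a direction for this change in this assay.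

The best anchor for compound 3 is the limit of compound 2, > 5000 nM, so compound 3 is expected to stay near it, most likely again as a limit. The expected change is a step that the limit leaves unreadable from compound 2 to compound 3, with no firm direction. For compound 3 the estimated value is 6000 nM, with an expected range from 2000 nM to 15000 nM.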

Compound 3, half-maximal inhibitory concentration: > 5000 nM
Compound 3 was reported as a limit; the forecaster's own chance of this, stated with the estimate: 75%; the middle value does not contradict the limit.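

In this assay compound 3 gives > 5000 nM, again a limit of the assay and not a number. The steps linking compound 3 to compound 1 and compound 2 therefore cannot be read: the limit of > 5000 nM in this assay, at which 3 of the 3 values shown sit. The compounds shown leave open how strongly each one inhibits, and whether swapping fluoro for chloro or adding methoxy changes that at all.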